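Methyl to Fluoro: an Expected Step in Cell Toxicity

A few compounds are considered here, and "the series" means these few. Any claim that something is new, unique, unknown or untested is made for them only; others in the source may bear on it.

In an ADME assay on NIH3T3 cells (Mus musculus) for cytotoxicity, read by CCK-8 assay, with a stated time of 24 h (on this read-out higher numbers stand for weaker inhibition and lower numbers for stronger inhibition), compound 2 `C/C(=C\c1ccc(-c2ccc(C)cc2)o1)C(N)=O` is reported only as a limit, > 50000 nM. Compound 1 `C/C(=C\c1cc(C2=CCCC2)co1)C(N)=O` gives 49300 nM in this assay. Compound 3 `C/C(=C\c1ccc(-c2ccc(F)cc2)o1)C(N)=O` differs from compound 2 by fluoro in place of methyl on an aromatic carbon. Within the data shown here, because of the limit of > 50000 nM in this assay, at which 1 of the 2 values shown sits, no measured step is available to gauge this exchange. Swapping one small group for another is expected to move the read-out by no more than the usual scatter, in no clear direction. Compound 3 is therefore expected to give about 50000 nM, between 20000 nM and 100000 nM. The step this expectation implies is a number no higher from compound 2 to compound 3 (the limit leaves the size open).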

Compound 3, half-maximal inhibitory concentration: 960 nM
Compound 3: middle estimate off by 52-fold (1.72 log units), on the high side; the measured number lies below the stated range.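

In this assay, fluoro in place of methyl gives an at least 52-fold lower number from compound 2 to compound 3 (1.71 log units; beyond the scatter), so on this aromatic carbon, para to a large group, an exchange of one heavy atom can strongly change the read-out and yield stronger inhibition of the cells. Compound 2 is reported only as a limit, so the step has a smallest size but no exact one: the limit of > 50000 nM in this assay, at which 1 of the 3 values shown sits.

On these data alone, whether this shift belongs to fluoro in particular or to the loss of methyl remains open. A chloro or methoxy group at the same place would help to separate the two.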